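The source may hold more compounds than are shown below. What is called first, only, known or untested is meant among the compounds shown, and "the series" means these compounds.

Compound 1 `C/C(=N\Cc1cccnc1)c1cccc(N)c1` in a functional assay on the whole organism (strain Swiss albino) with Mus musculus as the target, with a stated time of 4 h (a lower number here means that less compound is needed, a higher number that more compound is needed for the effect), gives 100 mg/kg.
Compound 2 `O=[N+]([O-])c1ccc(/C=N/Cc2cccnc2)cc1` in this assay gives 100 mg/kg.
Compound 3 `C(=N/Cc1cccnc1)\c1c[nH]c2ccccc12` in this assay gives 100 mg/kg.

On these numbers compound 2 stands level with compounds 1 and 3 at the digits shown. Its nearest neighbour is compound 1 and its furthest is compound 3, and in neither case does the gap go beyond the usual scatter of this kind of measurement.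

Compound 4 `Clc1ccc(/C=N/Cc2cccnc2)cc1` has not yet been measured. It differs from compound 2 in one place: chloro in place of nitro on an aromatic carbon. Going by the values given here, no step between measured compounds is known, and the three measured values all sit at one level, so they give no direction to read from. The expected step is no change at the digits printed from compound 2 to compound 4 (within the scatter), which means none beyond the scatter. Compound 4 is therefore estimated to give 100 mg/kg in this assay, with a likely range from 30 mg/kg to 300 mg/kg.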

Compound 4, minimum effective dose: 300 mg/kg
Estimate against measurement, compound 4: 3.0-fold (0.48 log units) below; the range from low to high includes it.
By their numbers in this assay, from the lowest: compounds 1, 2 and 3 (each within the scatter of the next); then compound 4.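

In this assay, chloro in place of nitro on an aromatic carbon gives a 3.0-fold higher number from compound 2 to compound 4 (0.48 log units; beyond the scatter), so more compound is needed for the effect. The earlier compounds shown here, all level, showed no step, whereas this pair shows that the group at this place, para to a group of 9 heavy atoms, can change the dose needed. Nothing measured here offers a reason for this step.

A single pair leaves open how an amine, a methoxy group or plain hydrogen would read at this place. It also leaves open whether the same change would give a similar step on another core.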